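The source may hold more compounds than are shown below. What is called first, only, known or untested is meant among the compounds shown, and "the series" means these compounds.

This account follows three ureas that share one core, and a fourth whose number was still to come. In an ADME assay on HEK293 cells (Homo sapiens) for cytotoxicity, with a stated time of 72 h (a lower number here means that less compound is needed, a higher number that more compound is needed for the effect), compound 1, `Cc1cc(NC(=O)Nc2ccccc2C(F)(F)F)c2ccccc2n1`, gives > 25000 nM, which is a limit of the assay rather than a number. Compound 3, `Cc1cc(NC(=O)Nc2cccc([N+](=O)[O-])c2)c2ccccc2n1`, likewise shows only a limit in this assay, > 25000 nM. Compound 2, `Cc1cc(NC(=O)Nc2ccc(N)cc2)c2ccccc2n1`, stands in this assay at > 25000 nM, again a limit and not a number. All three values shown sit at the limit of > 25000 nM in this assay, at which 3 of the 3 values shown sit, so compound 2 cannot be placed above or below its companions, and no order among the three can be read.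

Compound 4, `Cc1cc(NC(=O)Nc2ccc(Cl)cc2)c2ccccc2n1`, differs from compound 2 in a single place: chloro in place of amino on an aromatic carbon. Among the measured compounds shown here, no step between two measured compounds is available to guide the change. For the measured compounds named here, the expected step that the limit leaves unreadable from compound 2 to compound 4 is none beyond the scatter, because every value measured so far sits at the limit of > 25000 nM in this assay, at which 3 of the 3 values shown sit. Compound 4 is therefore estimated at 30000 nM in this assay, with a range from 12000 nM to 100000 nM, most likely reported again only as a limit.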

Compound 4, half-maximal effective concentration: > 25000 nM
Compound 4: no number, only a limit (the forecaster's own chance of this, stated with the estimate: 75%); the middle value does not contradict the limit.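

No step can be read from compound 2 to compound 4 in this assay because both show only a limit, not a number: the limit of > 25000 nM in this assay, at which 4 of the 4 values shown sit. The compounds shown leave open how these four ureas rank and at what concentration any of them would reach the half-maximal effect.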